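Azidoacetyl amide replacing the dienamide on compound 1

The compounds below may be only part of what the source reports. "The series", "measured", "known", "first", "only" and "open" are said of these compounds alone.

Measured compounds in a functional assay on MGC-803 cells (Homo sapiens) for inhibition, read by MTT assay, with a stated time of 48 h; on this read-out lower numbers stand for stronger inhibition and higher numbers for weaker inhibition:
compound 1 `C/C=C/C=C/C(=O)N(Cc1ccc(OC)c(O)c1)c1cc(OC)c(OC)c(OC)c1`: 140 nM
compound 2 `COC(=O)c1cc(CNc2cc(OC)c(OC)c(OC)c2)ccc1OC`: 49600 nM
compound 3 `COc1cc(NCc2ccccc2)cc(OC)c1OC`: > 80000 nM (a limit of this assay, not a number)

Compound 1 gives the lowest number of the two numbers in hand; compound 2 sits far higher, a gap well beyond the scatter. For compound 3 only a limit is known, (the limit of > 80000 nM in this assay, at which 1 of the 3 values shown sits). Within the data shown here, no pair among the measured compounds differs in a single place, so no measured step exists to lean on.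

Compound 4 `COc1ccc(CN(C(=O)CN=[N+]=[N-])c2cc(OC)c(OC)c(OC)c2)cc1O` keeps the shared core of compound 1 and its acylated nitrogen but changes the acyl group: azidomethyl in place of penta-1,3-dien-1-yl on a carbonyl carbon. The penta-1,3-dien-1-yl chain is lost and a short azidomethyl group takes its place on the carbonyl carbon. Among the measured compounds shown here, nothing among the measured compounds tells how this assay answers that exchange; the only guide is that compound 1, the sole acylated member, stands far ahead of the unacylated compound 2 and compound 3.

The step from compound 1 to compound 4 is expected to run towards weaker inhibition, an 11-fold higher number from compound 1 to compound 4 (1.03 log units; beyond the scatter), beyond the scatter. For compound 4 in this assay the estimate is 1500 nM, within 300 nM to 10000 nM.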

Compound 4, half-maximal inhibitory concentration: 120 nM
Beside the measured number, compound 4's estimate is 13-fold (1.10 log units) above it; the measured number lies below the stated range.
By their numbers in this assay, from the lowest: compounds 4 and 1 (each within the scatter of the next); then compound 2. At a limit, above all of these: compound 3.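

In this assay, the carbonyl carbon on the amide-type nitrogen accepts azidomethyl in place of penta-1,3-dien-1-yl with no change beyond the scatter: a 1.2-fold lower number from compound 1 to compound 4 (0.07 log units; within the scatter). The earlier compounds shown here offered no single-place step, and this one shows that inhibition at this level does not depend on the penta-1,3-dien-1-yl chain, since a group without any carbon-carbon double bond serves equally well in this assay. Nothing in the evidence at hand bears on why the two acyl groups read alike.

Still open, as far as these compounds go, is how aminomethyl, carboxymethyl or a longer azidoalkyl chain would read on the same carbonyl carbon. Also open, from the compounds shown here alone, is whether the azide itself contributes, as set against a plain methyl group in its place.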